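The source may hold more compounds than are shown below. What is called first, only, known or untested is meant among the compounds shown, and "the series" means these compounds.

Compound 1, `CC(C)c1sc(-c2ccccc2)c(C2CCCC2)c1/C=C/[C@@H](O)C[C@@H](O)CC(=O)O`, holds the lowest of the two numbers measured in an assay on microsomes for inhibition of 3-hydroxy-3-methylglutaryl-coenzyme A reductase (Rattus norvegicus); a lower number here means a stronger inhibitor, a higher number a weaker inhibitor: compound 1 gives 417 nM. Going by the values given here, its only measured neighbour is compound 2, `CC(C)c1sc(-c2ccccc2)c(-c2cccc(C(F)(F)F)c2)c1/C=C/[C@@H](O)C[C@@H](O)CC(=O)O`, which in this assay gives 2980 nM. The step of a 7.1-fold higher number from compound 1 to compound 2 (0.85 log units; beyond the scatter) exchanges the cyclopentyl group for 3-(trifluoromethyl)phenyl and makes the inhibitor weaker by a modest margin.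

The unmeasured compound 3, `CC(C)c1sc(-c2ccccc2)c(-c2ccc(-c3ccccc3)cc2)c1/C=C/[C@@H](O)C[C@@H](O)CC(=O)O`, differs from compound 1 on the same aromatic carbon: 4-phenylphenyl in place of cyclopentyl on an aromatic carbon. Among the compounds with values here, the one measured step that bears on this change is the one from compound 1 to compound 2, in which a six-membered aromatic ring took the place of cyclopentyl and the number in this assay rose beyond the scatter. Within the data shown here, compound 3 carries a larger aromatic replacement, 4-phenylphenyl, so the same direction is expected, and a step of comparable or somewhat greater size than the one seen for compound 2 seems likely. Compound 3 is therefore expected to give about 4000 nM in this assay, with a range of 1200 nM to 13000 nM. The expected step is a 9.6-fold higher number from compound 1 to compound 3 (0.98 log units; beyond the scatter).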

Compound 3, half-maximal inhibitory concentration: > 10000 nM
Compound 3: only a limit was reported (the forecaster's own chance of this, stated with the estimate: 5%); at least 2.5-fold (0.39 log units) between middle value and limit.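

With the new result, the change at this aromatic carbon reads beyond a single aromatic replacement: in this assay, 4-phenylphenyl gives an at least 23-fold higher number from compound 1 to compound 3 (1.37 log units; beyond the scatter) against cyclopentyl and an at least 3.3-fold higher number from compound 2 to compound 3 (0.52 log units; beyond the scatter) against 3-(trifluoromethyl)phenyl. The three groups therefore fall in one order, with the number rising from cyclopentyl through 3-(trifluoromethyl)phenyl to 4-phenylphenyl, and none of the three compounds goes against that order, so the two-ring aromatic group is the least tolerated of those shown at this carbon. The result for compound 3 is a limit and not a number, so both steps are open-ended on the upper side: the limit of > 10000 nM in this assay, at which 1 of the 3 values shown sits.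

The compounds shown leave open whether the rise follows the size of the group or the presence of an aromatic ring, as the non-aromatic cyclopentyl is also the smallest of the three groups. A cyclohexyl or an unsubstituted phenyl group on this carbon would begin to separate those two readings, and a short chain such as isopropyl would show whether any ring is needed there at all.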